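The compounds below may be only part of what the source reports. "The series", "measured", "known", "first", "only" and "open" are said of these compounds alone.

In a functional assay on DU-145 cells (Homo sapiens) for inhibition, read by MTT assay, with a stated time of 72 h (on this read-out lower numbers stand for stronger inhibition of growth and higher numbers for weaker inhibition of growth), three compounds carry a result. Compound 1 `N#C/C(=C\c1ccc(Cl)cc1)C(=O)c1ccc[nH]1` gives 61000 nM. For compound 2 `N#C/C(=C\c1c(F)c(F)c(F)c(F)c1F)C(=O)c1ccc[nH]1` the assay reports only a limit, > 100000 nM, as described in the limit of > 100000 nM in this assay, at which 1 of the 3 values shown sits. Compound 3 `COc1ccc(CNC(=O)/C(C#N)=C/c2ccco2)cc1` gives 29000 nM, the lower of the two numbers, with compound 1 the nearest at a gap beyond the scatter. Compound 4 `COc1ccc(CNC(=O)/C(C#N)=C/c2ccoc2)cc1` has not yet been measured; it differs from compound 3 only in furan-3-yl in place of furan-2-yl on a double-bonded chain carbon bound to a double-bonded chain carbon. Among the measured compounds shown here, no comparable step between measured compounds is available, so the expectation rests on the change itself: the step of a 1.2-fold higher number from compound 3 to compound 4 (0.08 log units; within the scatter) is expected to be small, if anything toward weaker inhibition, and may well lie within the scatter. Compound 4 is therefore estimated at 35000 nM, between 12000 nM and 100000 nM.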

Compound 4, concentration for 50% growth inhibition: 7000 nM
For compound 4 the middle estimate is 5.0-fold (0.70 log units) above the measured one; measured number outside the range, below it.
By their numbers in this assay, from the lowest: compound 4; then compound 3; then compound 1. At a limit, above all of these: compound 2.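

In this assay, moving only the point of attachment of the furan ring gives a 4.1-fold lower number from compound 3 to compound 4 (0.62 log units; beyond the scatter) with the atoms unchanged. Among the compounds shown here, this is the first comparison in this set between measured compounds that differ in one place, and it shows that the number at this place on a double-bonded chain carbon depends on how the ring is joined, not only on which ring is present. Nothing given here accounts for the size or direction of this step. From the compounds shown here alone, whether a thiophen-3-yl or pyridin-3-yl group at this place would match furan-3-yl remains open, as does whether the same step would hold on another core.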